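The source may hold more compounds than are shown below. What is called first, only, known or untested is meant among the compounds shown, and "the series" means these compounds.

Measured so far in a functional assay on A549 cells (Homo sapiens) for cytotoxicity, read by sulforhodamine B assay, with a stated time of 72 h; on this read-out lower numbers stand for stronger inhibition and higher numbers for weaker inhibition
compound 1 `CC(=O)Nc1ccn([C@@H]2CO[C@H](CO)O2)c(=O)n1` gives 6870 nM as its value
compound 2 `O=C(Nc1ccn([C@@H]2CO[C@H](CO)O2)c(=O)n1)c1ccccc1` gives 8530 nM as its value

Compound 2 at 8530 nM stands level with compound 1 within the scatter, so the pair marks a single band of values and no order.

Next in the series is compound 3 `O=C(Nc1ccn([C@@H]2CO[C@H](CO)O2)c(=O)n1)c1ccc(Cl)cc1Cl`, which keeps the shared core and carries 2,4-dichlorophenyl in place of phenyl on a carbonyl carbon as its only change. Among the compounds with values here, one measured step bears on this, phenyl in place of methyl at that same carbonyl carbon. It came out as a 1.2-fold higher number from compound 1 to compound 2 (0.09 log units; within the scatter) and stayed within the scatter. Within the data shown here, no compound with chlorine on the phenyl has been measured, so this single step is a thin guide and the range must stay wide. No step beyond the scatter is expected in this assay, and two compounds give no basis for a direction. The estimate is a 1.2-fold lower number from compound 2 to compound 3 (0.09 log units; within the scatter) as an expected step, no larger than the scatter. Expected for compound 3 is 7000 nM with 2500 nM to 18000 nM as the estimated range.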

Compound 3, half-maximal inhibitory concentration: 9830 nM
Compound 3: middle estimate off by 1.4-fold (0.15 log units), on the low side; the range from low to high includes it.
By their numbers in this assay, from the lowest: compounds 1, 2 and 3 (each within the scatter of the next).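

In this assay the step to 2,4-dichlorophenyl on a carbonyl carbon whose other neighbour is the amide-type nitrogen is a 1.2-fold higher number from compound 2 to compound 3 (0.06 log units; within the scatter) and adds a substituted aryl group to the two groups already seen at this place. The pair with the greatest difference in group, methyl against 2,4-dichlorophenyl, gives a 1.4-fold higher number from compound 1 to compound 3 (0.16 log units; within the scatter) and so also stays inside the scatter, which puts methyl, phenyl and 2,4-dichlorophenyl in one band of values with no order among them. The series therefore shows that neither an aryl group nor chlorine on that aryl group separates these compounds in this read-out, and no measurement at hand offers an explanation for this flat result.

Open, as far as these compounds go, is whether any group on this carbonyl carbon can move the value beyond the scatter, for example a longer alkyl chain, a carboxylic acid or an aminoalkyl chain. Also open, from the compounds shown here alone, is how a free amine in place of the acylated nitrogen would compare, and whether a single chlorine on the phenyl would stay in the same band.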